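Swapping an acetylated thiophene for a methylated pyrrole

The source may report more compounds than this note shows. Statements on the series, on what has been measured and on what is new or still open speak of the compounds shown alone.

Of the compounds shown here, three sharing one core have been measured in a functional assay on MV4-11 cells (Homo sapiens) for inhibition, read by resazurin assay, with a stated time of 72 h; on this read-out lower numbers stand for stronger inhibition of growth and higher numbers for weaker inhibition of growth. Compound 1 `Cc1csc(-c2cncc(Cl)c2N2CCC3(CCNC3=O)CC2)c1` gives 650 nM, and compound 2 `O=C1NCCC12CCN(c1c(Cl)cncc1-c1ccc(Cl)s1)CC2` gives 560 nM. With a 1.2-fold lower number from compound 1 to compound 2 (0.06 log units; within the scatter), these two cannot be told apart. Compound 3 `CC(=O)c1ccc(-c2cncc(Cl)c2N2CCC3(CCNC3=O)CC2)s1` gives 1440 nM, the highest number of the three. The steps leading to it are modest but beyond the scatter: a 2.2-fold higher number from compound 1 to compound 3 (0.35 log units; beyond the scatter), and a 2.6-fold higher number from compound 2 to compound 3 (0.41 log units; beyond the scatter).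

Compound 4 `Cn1cccc1-c1cncc(Cl)c1N1CCC2(CCNC2=O)CC1` has not yet been measured. It carries 1-methyl-1H-pyrrol-2-yl in place of 5-acetylthiophen-2-yl on an aromatic carbon, (1-methyl-1H-pyrrol-2-yl in place of 5-acetylthiophen-2-yl on an aromatic carbon). Among the measured compounds shown here, no measured step exchanges a thiophene for a pyrrole, so the data bear on this change only in part. For the measured compounds named here, what they do show is that compound 3 is the only acetyl-bearing compound, and that the steps into it, a 2.2-fold higher number from compound 1 to compound 3 (0.35 log units; beyond the scatter) and a 2.6-fold higher number from compound 2 to compound 3 (0.41 log units; beyond the scatter), both raise the number. Compound 4 also lacks the acetyl, so a return towards the level of compound 1 at 650 nM is expected, though the new ring leaves this uncertain. The expected change is a 1.8-fold lower number from compound 3 to compound 4 (0.26 log units; within the scatter), modest in size. Compound 4 is estimated at 800 nM, with an expected range from 350 nM to 1800 nM.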

Compound 4, concentration for 50% growth inhibition: 900 nM
Estimate against measurement, compound 4: 1.1-fold (0.05 log units) below, within the range that was stated.
By their numbers in this assay, from the lowest: compounds 2, 1, 4 and 3 (each within the scatter of the next, the first and the last beyond it).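

Up to compound 3, the changes at this position, on an aromatic carbon of the six-membered ring, had altered only the group carried by a thiophene, whereas compound 4 replaces the thiophene itself with 1-methyl-1H-pyrrol-2-yl, so that sulfur leaves the five-membered ring and nitrogen enters it. In this assay, this change to the ring gives steps within the scatter against all three thiophenes: a 1.6-fold lower number from compound 3 to compound 4 (0.20 log units; within the scatter), a 1.6-fold higher number from compound 2 to compound 4 (0.21 log units; within the scatter) and a 1.4-fold higher number from compound 1 to compound 4 (0.14 log units; within the scatter), so compound 4 cannot be told apart from any of them, even though compound 3 lies beyond the scatter of both compound 1 and compound 2. Nothing available explains why the pyrrole is tolerated here.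

Compound 4 changes the ring and its substituent together, so the part played by the methyl group on the pyrrole nitrogen stays unresolved, as does the outcome with a bare pyrrole carrying a hydrogen there. Also open, from the compounds shown here alone, is whether a pyrrole bearing a carboxylic acid or an aminomethyl group, or a phenyl ring at this position, would move the number beyond the scatter.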